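The compounds below may be only part of what the source reports. "The series", "measured", "known", "first", "only" and "open" are said of these compounds alone.

Measured so far:
Compound 1 `CNC(=O)c1sc2ncccc2c1N` — > 100000 nM
Compound 2 `NC(=O)c1sc2ccccc2c1N` — 33000 nM
Compound 3 `CN(C)C(=O)c1sc2ncccc2c1N` — > 100000 nM

All three were tested in an assay on isolated protein for inhibition of LIM domain kinase 1 (Homo sapiens), read by Kinase-Glo, with a stated time of 60 min; a higher number here means a weaker inhibitor, a lower number a stronger inhibitor. For compound 1 the result is a limit of the assay, not a number. For compound 3 the result is likewise a limit. Only compound 2 gives an actual number, 33000 nM. Compound 1 and compound 3 differ in one place, (methyl in place of hydrogen on an amide-type nitrogen), yet the step that the two limits leave unreadable from compound 1 to compound 3 cannot be sized because the limit of > 100000 nM in this assay, at which 2 of the 3 values shown sit, holds both values.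

The difference between the core of compound 2 and the core of compound 1 is not broken down here.

Compound 4 `CNc1c(C(N)=O)sc2ccccc12` has not been measured. It differs from compound 2 by methyl in place of hydrogen on a nitrogen on an aromatic ring. This is the same kind of change as that from compound 1 to compound 3, but not the same: there the place was an amide-type nitrogen whose other neighbours are a carbonyl carbon and a saturated chain carbon, here it is a nitrogen on an aromatic ring whose other neighbour is an aromatic carbon. The measured pair gives no readable step, so the expectation for compound 4 rests only on compound 2 at 33000 nM and on a methyl being a small addition. Compound 4 is estimated at 50000 nM, within 15000 nM to 200000 nM, an expected step of a 1.5-fold higher number from compound 2 to compound 4 (0.18 log units; within the scatter).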

Compound 4, half-maximal inhibitory concentration: 34000 nM
Compound 4: middle estimate off by 1.5-fold (0.17 log units), on the high side; the measured number falls inside the stated range.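

In this assay, methyl in place of hydrogen on a nitrogen on an aromatic ring gives a 1.0-fold higher number from compound 2 to compound 4 (0.01 log units; within the scatter) on the core of compound 2, so the amino and methylamino compounds cannot be told apart here. This is a single pair on a single core, and it does not show that the same change would behave alike on the core of compound 1, where no compound shown carries a methyl on that kind of nitrogen. For the compounds shown here, the only methyl step on the core of compound 1 sits on an amide-type nitrogen and cannot be read, because the results for compound 1 and compound 3 are both limits and not numbers: the limit of > 100000 nM in this assay, at which 2 of the 4 values shown sit.

Still open, as far as these compounds go, is whether a group larger than methyl on the nitrogen on an aromatic ring, such as ethyl or a longer chain, would also match compound 2. Also open, from the compounds shown here alone, is how a carboxylic acid in place of the amide would read on either core.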